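A Carboxy End Swapped for Hydroxymethyl

The compounds below may be only part of what the source reports. "The series", "measured", "known", "first", "only" and "open" are said of these compounds alone.

In a functional assay on Caco-2 cells (Homo sapiens) for antiproliferative activity, read by MTT assay, with a stated time of 48 h (a lower number here means a stronger inhibitor, a higher number a weaker inhibitor), compound 2 `CCn1c(C(=O)N(C)CC(=O)O)ccc1C(CC)(CC)c1ccc(OCCC(O)(CC)CC)c(C)c1` gives 2740 nM, and compound 1 `CCN(CC)CCNC(=O)c1ccc(C(CC)(CC)c2ccc(OCCC(O)(CC)CC)c(C)c2)n1CC` gives 1630 nM. For the measured compounds named here, these are the only two numbers so far, and they lie within the scatter of each other. Compound 3 `CCn1c(C(=O)N(C)CCO)ccc1C(CC)(CC)c1ccc(OCCC(O)(CC)CC)c(C)c1` keeps the core of compound 2 and alters only the end of its side chain: hydroxymethyl in place of carboxy on a saturated chain carbon bound to an amide-type nitrogen. In short, hydroxymethyl stands in place of carboxy on a saturated chain carbon bound to an amide-type nitrogen. Going by the values given here, no measured step makes this exact swap. The closest one, a 1.7-fold higher number from compound 1 to compound 2 (0.23 log units; within the scatter), exchanged the whole amino group on the carbonyl carbon, so a change inside that group is expected to give no step beyond the scatter in this assay. The estimated change is a 1.3-fold lower number from compound 2 to compound 3 (0.12 log units; within the scatter). For compound 3 the expected value is 2100 nM, with an estimated range of 1000 nM to 4500 nM.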

Compound 3, half-maximal inhibitory concentration: 74 nM
The estimate for compound 3 lay 28-fold (1.45 log units) above the measured number; the measured number lies below the stated range.
By their numbers in this assay, from the lowest: compound 3; then compounds 1 and 2 (each within the scatter of the next).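

For the compounds shown here, the end of this side chain matters far more than the earlier compounds suggested: in this assay hydroxymethyl in place of carboxy gives a 37-fold lower number from compound 2 to compound 3 (1.57 log units; beyond the scatter) and so counts as a large step, although only the end of the side chain differs. The earlier exchange on the carbonyl carbon, a 1.7-fold higher number from compound 1 to compound 2 (0.23 log units; within the scatter) and within the scatter, had hinted at little sensitivity here, yet the exchange of (2-(diethylamino)ethyl)amino for (2-hydroxyethyl)(methyl)amino gives a 22-fold lower number from compound 1 to compound 3 (1.34 log units; beyond the scatter) and is also large. No measurement at hand explains why this swap has such an effect.

Open, as far as these compounds go, is whether the free hydroxyl end of the 2-hydroxyethyl chain is needed, which a 2-methoxyethyl or 2-aminoethyl group in its place could test. Also open, from the compounds shown here alone, is whether a longer chain such as 3-hydroxypropyl would keep the low number.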